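Replacing 3-nitrophenyl with 4-cyanophenyl in compound 3

The compounds below may be only part of what the source reports. "The series", "measured", "known", "first", "only" and "open" are said of these compounds alone.

Values measured so far in a functional assay on HepG2 cells (Homo sapiens) for cytotoxicity, read by MTT assay, with a stated time of 24 h (a higher number here means a weaker inhibitor, a lower number a stronger inhibitor), are these:
Compound 1 `COc1cc(/C=C2\CN(S(=O)(=O)c3ccc(F)cc3)C/C(=C\c3ccc(C#N)cc3)C2=O)cc(OC)c1OC` gives 4950 nM
Compound 2 `COc1cc(/C=C2\CN(S(=O)(=O)c3ccc(NC(C)=O)cc3)C/C(=C\c3ccccc3F)C2=O)cc(OC)c1OC` gives 4750 nM
Compound 3 `COc1cc(/C=C2\CN(S(=O)(=O)c3ccc(NC(C)=O)cc3)C/C(=C\c3cccc([N+](=O)[O-])c3)C2=O)cc(OC)c1OC` gives 3340 nM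

All three values lie within the usual scatter of one another, so compound 3 stands level with compound 1 and compound 2, and the three cannot be ranked. The next compound, compound 4 `COc1cc(/C=C2\CN(S(=O)(=O)c3ccc(NC(C)=O)cc3)C/C(=C\c3ccc(C#N)cc3)C2=O)cc(OC)c1OC`, has 4-cyanophenyl in place of 3-nitrophenyl on a double-bonded chain carbon bound to a double-bonded ring carbon. Among the measured compounds shown here, only one measured step changes the group at this place. It is a 1.4-fold lower number from compound 2 to compound 3 (0.15 log units; within the scatter) and one such step is thin evidence. Compound 1 also carries 4-cyanophenyl here and gives 4950 nM in the same range, though it differs from compound 4 elsewhere. No step beyond the scatter is therefore expected in this assay for this swap. The expected size is a 1.3-fold higher number from compound 3 to compound 4 (0.10 log units; within the scatter) and no direction can be relied on. For compound 4 the estimated value is 4200 nM with an expected range from 2400 nM to 7000 nM as the likely span.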

Compound 4, half-maximal inhibitory concentration: 2890 nM
The estimate for compound 4 lay 1.5-fold (0.16 log units) above the measured number; the range from low to high includes it.
By their numbers in this assay, from the lowest: compounds 4, 3, 2 and 1 (each within the scatter of the next).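

In this assay, three different aromatic groups at this place, 2-fluorophenyl, 3-nitrophenyl and 4-cyanophenyl, can now be compared on otherwise matching compounds, and neither a 1.2-fold lower number from compound 3 to compound 4 (0.06 log units; within the scatter) nor a 1.6-fold lower number from compound 2 to compound 4 (0.22 log units; within the scatter) leaves the scatter, so this position shows no measurable preference among them. Among the compounds shown here, a second place can also be read for the first time: acetamido in place of fluoro on an aromatic carbon gives a 1.7-fold lower number from compound 1 to compound 4 (0.23 log units; within the scatter), which also stays within the scatter. Nothing at hand bears on why these numbers stay so close.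

From the compounds shown here alone, what remains open is whether any change at either place can move the number beyond the scatter. A carboxylic acid or an amine on the aromatic ring, or a saturated cyclohexyl ring in its stead, could test this at the first place, and a free amine in place of acetamido at the second.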